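Swapping Methyl for Methoxy on the Phenylpyrazole Arm

The compounds below may be only part of what the source reports. "The series", "measured", "known", "first", "only" and "open" are said of these compounds alone.

Compound 1 `O=C(Nc1cnn(-c2ccccc2)c1)c1cccc(NS(=O)(=O)c2ccc(Cl)cc2)c1` carries a plain phenyl on its shared core. In a functional assay on HepG2 cells (Homo sapiens) for inhibition, read by MTT assay, with a stated time of 48 h (a lower number here means a stronger inhibitor, a higher number a weaker inhibitor), compound 1 gives 8540 nM. Compound 2 `Cc1ccc(-n2cc(NC(=O)c3cccc(NS(=O)(=O)c4ccc(Cl)cc4)c3)cn2)cc1` differs only by a methyl on an aromatic carbon of that phenyl, and in this assay compound 2 gives 2440 nM. That single change produced a 3.5-fold lower number from compound 1 to compound 2 (0.54 log units; beyond the scatter). Within the data shown here, of the two numbers measured, compound 2 holds the lower one, and its only neighbour, compound 1, sits a clear step higher.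

Compound 3 `COc1ccc(-n2cc(NC(=O)c3cccc(NS(=O)(=O)c4ccc(Cl)cc4)c3)cn2)cc1` again changes just one place: methoxy in place of methyl on an aromatic carbon. Among the measured compounds shown here, only one measured step bears on this, a 3.5-fold lower number from compound 1 to compound 2 (0.54 log units; beyond the scatter), which shows that what sits on this aromatic carbon can move the number, yet it compares hydrogen with methyl, not methyl with methoxy. Nothing measured tests a methoxy here. The expectation is therefore a step that stays within the scatter in this assay, in no clear direction, with a wide range to cover the uncertainty. Compound 3 is expected at 2500 nM, within a range from 800 nM to 8000 nM. The expected step is a 1.0-fold higher number from compound 2 to compound 3 (0.01 log units; within the scatter).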

Compound 3, half-maximal inhibitory concentration: 15200 nM
Estimate against measurement, compound 3: 6.1-fold (0.78 log units) below; the whole stated range lies below it.
By their numbers in this assay, from the lowest: compound 2; then compounds 1 and 3 (each within the scatter of the next).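

In this assay the identity of the group on this aromatic carbon matters, not merely whether one is present: replacing methyl with methoxy, which adds one oxygen, gives a 6.2-fold higher number from compound 2 to compound 3 (0.79 log units; beyond the scatter) and so undoes the advantage seen with the methyl. Set against the plain phenyl, the methoxy gives a 1.8-fold higher number from compound 1 to compound 3 (0.25 log units; within the scatter) and compound 3 therefore cannot be told apart from compound 1, which leaves the 4-methylphenyl of compound 2 as the only one of the three clearly separated from the others. No supporting measurement is available to explain why methyl and methoxy differ at this place.

With only hydrogen, methyl and methoxy compared, these compounds cannot show whether the lower number belongs to methyl alone or would also appear with an ethyl group, a chlorine atom or an amine at the same place. They also leave open whether the same swap from methyl to methoxy would give a step of similar size on a different part of the shared core.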